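A few compounds are considered here, and "the series" means these few. Any claim that something is new, unique, unknown or untested is made for them only; others in the source may bear on it.

Compound 1 `FC(F)(F)c1ccc(-c2ccc3c(NCCCNCc4ccco4)ccnc3c2)cc1` gives 237 10^-6 cm/s in an ADME assay for permeability, using PAMPA, with a stated time of 30 min, at pH 7.4 (a lower number here means that the compound crosses the layer more slowly, a higher number that the compound crosses the layer faster), the higher of the two numbers recorded so far; compound 2 `COc1cccc(CNCCCNc2ccnc3cc(CCC(C)C)ccc23)c1O` gives 23 10^-6 cm/s in the same assay, a gap beyond the usual scatter. Compound 3 `Clc1ccc(Oc2ccc3c(NCCCNCc4ccco4)ccnc3c2)cc1` has not yet been tested. It differs from compound 1 in one place: 4-chlorophenoxy in place of 4-(trifluoromethyl)phenyl on an aromatic carbon. Among the measured compounds shown here, no pair of measured compounds differs in a single place, so no measured step guides the estimate. In this assay the step of a 1.3-fold lower number from compound 1 to compound 3 (0.12 log units; within the scatter) is expected to be small, toward a slightly lower number, and within the scatter. Compound 3 is estimated at 180 10^-6 cm/s, with a range from 80 10^-6 cm/s to 350 10^-6 cm/s.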

Compound 3, apparent permeability: 317 10^-6 cm/s
Compound 3: middle estimate off by 1.8-fold (0.25 log units), on the low side; low and high end bracket the measured number.
By their numbers in this assay, from the lowest: compound 2; then compounds 1 and 3 (each within the scatter of the next).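

In this assay, 4-chlorophenoxy in place of 4-(trifluoromethyl)phenyl on this aromatic carbon gives a 1.3-fold higher number from compound 1 to compound 3 (0.13 log units; within the scatter), the first single-place step recorded at this position. The two groups therefore read alike here, even though the entering group brings an oxygen and a chlorine and has fewer heavy atoms. No measured evidence bears on the reason for this result. Still open, as far as these compounds go, is how a group without an aromatic ring, such as an amine, a carboxylic acid or a longer chain, would read on this carbon in this assay.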